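A few compounds are considered here, and "the series" means these few. Any claim that something is new, unique, unknown or untested is made for them only; others in the source may bear on it.

Compounds measured so far:
compound 1 `O=c1cc(CSC(=S)N2CCCCC2)oc2cc(Cl)ccc12`, > 25000 nM
compound 2 `O=c1cc(CSC(=S)N2CCCCC2)oc2ccccc12`, > 25000 nM

In a functional assay on HeLa cells (Homo sapiens) for antiproliferative activity, read by MTT assay, with a stated time of 72 h (on this read-out lower numbers stand for stronger inhibition and higher numbers for weaker inhibition), compound 1 gives > 25000 nM, a limit of the assay. Compound 2 likewise gives > 25000 nM, a limit. The step that the two limits leave unreadable from compound 1 to compound 2 is therefore of unreadable size; both values sit at the limit of > 25000 nM in this assay, at which 2 of the 2 values shown sit.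

Compound 3 `CCN(CC)C(=S)SCc1cc(=O)c2ccc(Cl)cc2o1` differs from compound 1 by diethylamino in place of piperidin-1-yl on a thiocarbonyl carbon. Among the measured compounds shown here, no measured step bears on this change. Compound 1 itself is known only as a limit, so compound 3 is expected to fall near the same limit, estimated at 40000 nM, from 15000 nM to 100000 nM. The expected step is a step that the limit leaves unreadable from compound 1 to compound 3.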

Compound 3, half-maximal inhibitory concentration: 8700 nM
Compound 3: middle estimate off by 4.6-fold (0.66 log units), on the high side, outside the stated range (below it).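

In this assay, among the compounds shown here, diethylamino in place of piperidin-1-yl on a thiocarbonyl carbon gives an at least 2.8-fold lower number from compound 1 to compound 3 (0.45 log units; beyond the scatter), the first readable change. The size is only a bound, as compound 1 is known only as a limit. The earlier hydrogen-for-chloro step cannot be read, so this thiocarbonyl substituent is the one place shown to respond: the limit of > 25000 nM in this assay, at which 2 of the 3 values shown sit.

On these data alone, whether dimethylamino, dipropylamino or a morpholine ring would move the number further remains open. So does whether chloro on the core matters once diethylamino is present.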